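Sulfonamide series: trimethoxyphenyl variant of compound 2

A few compounds are considered here, and "the series" means these few. Any claim that something is new, unique, unknown or untested is made for them only; others in the source may bear on it.

Measured so far:
- compound 1 `Cc1ccc(S(=O)(=O)N(Cc2ccccc2)Cc2cccc(F)c2F)cc1` — -35.7%
- compound 2 `Cc1ccc(S(=O)(=O)N(Cc2cn(Cc3ccccc3Cl)nn2)Cc2cn(S(=O)(=O)c3ccc(C)cc3)c3ccccc23)cc1` — -4.8%
- compound 3 `CC(=O)N(Cc1cccc(F)c1F)Cc1cn(S(=O)(=O)c2ccc(F)cc2)c2ccccc12` — 25.8%

In a functional assay on 3T3-L1 cells (Mus musculus) for inhibition, with a stated time of 20 min, tested at 20 uM (on this read-out higher numbers stand for more inhibition at the one concentration tested (going by the name of the read-out) and lower numbers for less inhibition), compound 3 gives 25.8%, compound 2 gives -4.8% and compound 1 gives -35.7%. Compound 2 stands second of the three, with compound 3 higher by a gap beyond the scatter and compound 1 lower by a gap of similar size, also beyond the scatter. Among the compounds with values here, none of these three pairs differs in only one place, so no single step between measured compounds is available.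

Compound 4 `COc1cc(OC)c(Cn2cc(CN(Cc3cn(S(=O)(=O)c4ccc(C)cc4)c4ccccc34)S(=O)(=O)c3ccc(C)cc3)nn2)c(OC)c1` is not yet measured. Its difference from compound 2 is 2,4,6-trimethoxyphenyl in place of 2-chlorophenyl on a saturated chain carbon bound to an aromatic nitrogen. Within the data shown here, no measured pair shows the effect of 2,4,6-trimethoxyphenyl in place of 2-chlorophenyl on a saturated chain carbon bound to an aromatic nitrogen, so there is no basis for expecting a shift in this assay beyond the scatter in either direction. Compound 4 is expected to give -3%, within -30% to 25%; the step of a number 1.8 percentage points higher from compound 2 to compound 4 (within the scatter) is therefore expected to be small.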

Compound 4, a percentage reported as inhibition, at one concentration (the size of the read-out at that concentration, not a potency): -22%
For compound 4 the middle estimate is 19 percentage points above the measured one, and the stated range covers the measured number.
By their numbers in this assay, from the lowest: compound 1; then compound 4; then compound 2; then compound 3.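

In this assay, within the data shown here, the change to 2,4,6-trimethoxyphenyl gives a number 17.2 percentage points lower from compound 2 to compound 4 (beyond the scatter) and is the only single-place step available. Among these compounds, it shows that the aryl group on a saturated chain carbon bound to an aromatic nitrogen can shift the read-out with the rest of the molecule held constant, which the earlier compounds, all differing in more than one place, could not show. No measurement available here accounts for this step.

This single step does not separate the loss of the chlorine from the entry of the methoxy groups, since both occur together. Also open, on these data alone, is how a carboxylic acid or a dimethylamino group on the phenyl ring at this place would read, and whether the step would recur on the acetamide of compound 3.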